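Removing the Carboxyethyl Chain from a Scaffold at the Limit

The compounds below may be only part of what the source reports. "The series", "measured", "known", "first", "only" and "open" are said of these compounds alone.

Compound 1 `Cn1nc(Cc2nnc(SCC(=O)Nc3ccc(Cl)cc3Cl)n2CCC(=O)O)c2ccccc2c1=O`, compound 2 `Cn1c(Cc2nn(CCCO[Si](C)(C)C(C)(C)C)c(=O)c3ccccc23)nnc1SCCCCCCCC(=O)Nc1ccc(Cl)cc1Cl` and compound 3 `Cn1c(Cc2nn(CCC(=O)O)c(=O)c3ccccc23)nnc1SCCCCCCCC(=O)Nc1ccc(Cl)cc1Cl` were all tested in an assay on 32D cells for inhibition of interleukin-15 (Mus musculus), read by resazurin assay, with stated times of 30 min and 2.5 days, in the presence of a further agent that is not named here; a higher number here means a weaker inhibitor, a lower number a stronger inhibitor. For compound 1 the result is only a limit of the assay, > 30000 nM. Compound 2 likewise gives only a limit, > 30000 nM. Compound 3 also reaches only the limit, > 30000 nM, so it stands at the ceiling described by the limit of > 30000 nM in this assay, at which 3 of the 3 values shown sit. The step that the two limits leave unreadable from compound 2 to compound 3 is for that reason unreadable. Compound 4 `Cn1c(Cc2n[nH]c(=O)c3ccccc23)nnc1SCCCCCCCC(=O)Nc1ccc(Cl)cc1Cl` differs from compound 3 by hydrogen in place of 2-carboxyethyl on an aromatic nitrogen. Among the compounds with values here, no measured step touches this change, and the one step on the neighbouring chain gives no readable size. Compound 4 is therefore expected to remain at the limit, with an estimated step of a number no higher from compound 3 to compound 4 (the limit leaves the size open). The estimate for compound 4 is 30000 nM, ranging from 8000 nM to 100000 nM.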

Compound 4, half-maximal inhibitory concentration: > 30000 nM
Compound 4: only a limit was reported; the forecaster's own chance of this, stated with the estimate: 80%; the middle value sits exactly at the limit.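

In this assay compound 4 gives only a limit, > 30000 nM, so the steps to it from compound 2 and compound 3 cannot be read. The compounds shown leave open which change to the shared core, if any, would give a readable value, with all of them at one ceiling: the limit of > 30000 nM in this assay, at which 4 of the 4 values shown sit.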